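The source may report more compounds than this note shows. Statements on the series, on what has been measured and on what is new or still open speak of the compounds shown alone.

Measured compounds:
compound 1, `COc1cccc(NC2=CC(=O)c3c(nc4n3[C@H]3OC[C@@H](O)[C@H]3OC4)C2=O)c1`, 1790 nM
compound 2, `Cc1ccc(NC2=CC(=O)c3nc4n(c3C2=O)[C@H]2OC[C@@H](O)[C@H]2OC4)cc1C`, 860 nM

Both compounds share the same core and differ only in the aryl group carried on the amine nitrogen. In a functional assay on MGC-803 cells (Homo sapiens) for inhibition, read by sulforhodamine B assay (a lower number here means a stronger inhibitor, a higher number a weaker inhibitor), compound 1 gives 1790 nM, the highest of the two numbers recorded. Within the data shown here, compound 2 gives 860 nM in this assay, a number that lies beyond the scatter below that of compound 1; no step between the two is computed, so their pair shows only that compound 2 sits lower.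

Compound 3, `O=C1C(NC2CC2)=CC(=O)c2c1nc1n2[C@H]2OC[C@@H](O)[C@H]2OC1`, has not yet been measured in this assay. It is reached from compound 1 by a single change: cyclopropyl in place of 3-methoxyphenyl on an amine nitrogen. Among the measured compounds shown here, both measured compounds carry a six-membered aromatic ring on that nitrogen, so no measured pair shows what follows when that ring gives way to a three-membered non-aromatic one. The step of a 2.0-fold higher number from compound 1 to compound 3 (0.29 log units; within the scatter) is therefore an estimate without a shown precedent, expected to run toward a higher number, beyond the scatter, with a wide range on either side. Compound 3 is expected to give about 3500 nM in this assay, within a range from 900 nM to 14000 nM.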

Compound 3, half-maximal inhibitory concentration: > 4000 nM
Compound 3: a limit, no number (the forecaster's own chance of this, stated with the estimate: 10%); at least 1.1-fold (0.05 log units) between middle value and limit.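

In this assay compound 3 gives > 4000 nM, which is a limit of the assay and not a number. The earlier compounds shown here both carried a six-membered aromatic ring on the amine nitrogen, so they could not show what happens when that ring goes; the swap of 3-methoxyphenyl for cyclopropyl now gives an at least 2.2-fold higher number from compound 1 to compound 3 (0.34 log units; beyond the scatter), the first measured sign that this position is not indifferent to such a change and that the smaller, non-aromatic group weakens inhibition on the core of compound 1. The size of this step is bounded on one side only, and how much weaker compound 3 really is remains unknown: the limit of > 4000 nM in this assay, at which 1 of the 3 values shown sits.

A single step cannot separate the loss of the aromatic ring from the loss of the methoxy oxygen or from the drop in the size of the group. The compounds shown also leave open how an unsubstituted phenyl, a benzyl group or a longer alkyl chain on the same amine nitrogen would read in this assay.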